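A few compounds are considered here, and "the series" means these few. Any claim that something is new, unique, unknown or untested is made for them only; others in the source may bear on it.

Measured so far:
Compound 1, `COc1ccc(/C=C/c2cc(/C=C/c3ccc(OC)cc3)nc(OCCCCCBr)n2)cc1`: > 20000 nM
Compound 2, `COc1cc(/C=C/c2cc(/C=C/c3cc(OC)c(OC)c(OC)c3)nc(OCCCCCCBr)n2)cc(OC)c1OC`: > 20000 nM

Both values recorded in a functional assay on HCT-116 cells (Homo sapiens) for cytotoxicity, read by fluorescence and resazurin assay, with a stated time of 48 h (a higher number here means a weaker inhibitor, a lower number a stronger inhibitor), are limits of the assay rather than numbers. Compound 1 reaches only the limit > 20000 nM in this assay. Compound 2 likewise reaches only the limit > 20000 nM in this assay. Compound 2 therefore stands at the limit of > 20000 nM in this assay, at which 2 of the 2 values shown sit, and nothing in the numbers shown separates it from compound 1. Among the measured compounds shown here, no step between measured compounds is available.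

Compound 3, `COc1cc(/C=C/c2cc(/C=C/c3cc(OC)c(OC)c(OC)c3)nc(OCCCCCBr)n2)cc(OC)c1OC`, is the unmeasured partner of compound 2. The change from compound 2 to compound 3 is bromo in place of bromomethyl on a saturated chain carbon, five bonds along the chain from an oxygen on an aromatic ring. For the measured compounds named here, since both measured compounds sit at the assay limit, no step of any size can be read from them, and no movement beyond the scatter is expected. The expected step is a step that the limit leaves unreadable from compound 2 to compound 3. Compound 3 is estimated at 30000 nM, with a range from 15000 nM to 100000 nM, and it will most likely again be reported only as a limit.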

Compound 3, half-maximal inhibitory concentration: > 20000 nM
Compound 3 was reported as a limit (the forecaster's own chance of this, stated with the estimate: 85%); the middle value is on the limit's open side.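

No step can be read from compound 2 to compound 3 in this assay, since both values are limits of the assay rather than numbers: the limit of > 20000 nM in this assay, at which 3 of the 3 values shown sit.

The compounds shown leave open whether bromo in place of bromomethyl changes the cytotoxicity at all.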